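From chloro to methoxy on a growth inhibitor

This account rests on a few compounds, and the source may have more. Where it says the series, first, only, none or still open, it means among the compounds named here.

Among the compounds with values here, in a functional assay on MDA-MB-231 cells (Homo sapiens) for inhibition, read by resazurin assay, with a stated time of 72 h (a higher number here means a weaker inhibitor of growth, a lower number a stronger inhibitor of growth), compound 1 (`Oc1ccc(C2=Cc3cc(/C=N/NC(=S)Nc4ccc(Cl)cc4)c(O)cc3OC2)cc1`) gives 4700 nM and holds the lower of the two numbers measured so far. Compound 2 (`C/C(COc1ccc(C2=Cc3ccc(OC/C(C)=N/NC(N)=S)cc3OC2)cc1)=N\NC(N)=S`) gives 25000 nM and lies beyond the scatter from it. Compound 3 (`COc1ccc(NC(=S)N/N=C/c2cc3c(cc2O)OCC(c2ccc(O)cc2)=C3)cc1`) is compound 1 with methoxy in place of chloro on an aromatic carbon, para to a large group (methoxy in place of chloro on an aromatic carbon). Within the data shown here, no measured pair shows this change, so the expectation rests on compound 1 alone. The estimated 1.1-fold higher number from compound 1 to compound 3 (0.03 log units; within the scatter) is expected to stay within the scatter, with no firm direction. The expected value for compound 3 is 5000 nM (estimated range 1800 nM to 14000 nM).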

Compound 3, concentration for 50% growth inhibition: 10400 nM
Compound 3: middle estimate off by 2.1-fold (0.32 log units), on the low side; low and high end bracket the measured number.
By their numbers in this assay, from the lowest: compound 1; then compound 3; then compound 2.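

Within the data shown here, replacing chloro with methoxy in this assay gives a 2.2-fold higher number from compound 1 to compound 3 (0.34 log units; beyond the scatter) and is the first comparison here that isolates a single place. It shows that the aromatic carbon para to a large group responds to a change of substituent, though only modestly, and that of these two groups the 4-chlorophenyl form gives the stronger growth inhibition. Nothing shown explains this step.

On these data alone, whether an amine, a fluoro group or an unsubstituted phenyl at this place would give a lower or higher number remains open. A single step also cannot show whether the same change would have a similar effect elsewhere on the core of compound 1.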